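From Compound 2 to Compound 3: A Small Chain Change

The source may hold more compounds than are shown below. What is called first, only, known or untested is meant among the compounds shown, and "the series" means these compounds.

- compound 1 `CC/C=C/C(=O)Nc1cccc(Oc2nc(Nc3ccc(OC)nc3)nc3c2CSCC3)c1`: 31500 nM
- compound 2 `COc1ccc(Nc2nc3c(c(Oc4cccc(NC(=O)C=C(C)C)c4)n2)CSCC3)cn1`: 22200 nM

In a functional assay on MCF7 cells (Homo sapiens) for antiproliferative activity, read by MTT assay, with a stated time of 72 h (on this read-out higher numbers stand for weaker inhibition and lower numbers for stronger inhibition), compound 2 gives 22200 nM, which lies within the scatter of compound 1 at 31500 nM. Compound 3 `COc1ccc(Nc2nc3c(c(Oc4cccc(NC(=O)/C=C/C(C)C)c4)n2)CSCC3)cn1` carries 3-methylbut-1-en-1-yl in place of 2-methylprop-1-en-1-yl on a carbonyl carbon. Among the measured compounds shown here, the only measured step at this place is a 1.4-fold lower number from compound 1 to compound 2 (0.15 log units; within the scatter), and it stays within the scatter. No shift beyond the scatter is therefore expected in this assay, and no direction can be expected with confidence. The estimated step is a 1.0-fold higher number from compound 2 to compound 3 (0.02 log units; within the scatter). Compound 3 is estimated at 23000 nM, with an expected range of 11000 nM to 46000 nM.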

Compound 3, half-maximal inhibitory concentration: 37100 nM
Estimate against measurement, compound 3: 1.6-fold (0.21 log units) below; low and high end bracket the measured number.
By their numbers in this assay, from the lowest: compounds 2, 1 and 3 (each within the scatter of the next).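

In this assay, 3-methylbut-1-en-1-yl in place of 2-methylprop-1-en-1-yl on the carbonyl carbon gives a 1.7-fold higher number from compound 2 to compound 3 (0.22 log units; within the scatter), while the methyl added to the saturated chain carbon gives a 1.2-fold higher number from compound 1 to compound 3 (0.07 log units; within the scatter). All three chains on this carbonyl carbon thus stay within the scatter of one another, so the branched chain with the extra carbon brings no readable change at this place. No evidence on the cause is available. From the compounds shown here alone, whether an amine or a carboxylic acid on this chain would move the number beyond the scatter remains open.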